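The compounds below may be only part of what the source reports. "The series", "measured", "known", "first", "only" and "open" are said of these compounds alone.

Compound 1 `CCc1ccc(-n2cc(COc3cccc(NC(=O)Nc4ccc(Cl)c(C(F)(F)F)c4)c3)nn2)cc1` carries a 4-ethylphenyl on an aromatic nitrogen. Within the data shown here, in a functional assay on HepG2 cells (Homo sapiens) for inhibition, read by MTT assay, with a stated time of 72 h (on this read-out higher numbers stand for weaker inhibition and lower numbers for stronger inhibition), compound 1 gives 1950 nM, the lowest of the two numbers measured so far, though compound 2 `O=C(Nc1cccc(OCc2cn(-c3ccccc3Cl)nn2)c1)Nc1ccc(Cl)c(C(F)(F)F)c1` with 1960 nM sits within the scatter of it: the change a 1.0-fold higher number from compound 1 to compound 2 (0.00 log units; within the scatter) put 2-chlorophenyl in place of 4-ethylphenyl on an aromatic nitrogen without moving the number. Compound 3 `O=C(Nc1cccc(OCc2cn(-c3ccc(Br)cc3)nn2)c1)Nc1ccc(Cl)c(C(F)(F)F)c1` differs from compound 1 by bromo in place of ethyl on an aromatic carbon. Among the measured compounds shown here, only that one earlier step bears on this change, and it was flat, so no step beyond the scatter is expected in this assay. Compound 3 is therefore expected near 2000 nM, between 800 nM and 5000 nM. The expected step is a 1.0-fold higher number from compound 1 to compound 3 (0.01 log units; within the scatter).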

Compound 3, half-maximal inhibitory concentration: 2730 nM
Beside the measured number, compound 3's estimate is 1.4-fold (0.14 log units) below it; the measured number falls inside the stated range.
By their numbers in this assay, from the lowest: compounds 1, 2 and 3 (each within the scatter of the next).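

In this assay, the step of a 1.4-fold higher number from compound 1 to compound 3 (0.15 log units; within the scatter) shows that bromo can replace ethyl at this place on the ring with no change beyond the scatter. The step of a 1.4-fold higher number from compound 2 to compound 3 (0.14 log units; within the scatter) adds a third aryl group on the aromatic nitrogen, and 4-ethylphenyl, 2-chlorophenyl and 4-bromophenyl all remain within the scatter. No measured evidence here explains this flat result. The compounds shown leave open whether an amine, a carboxylic acid or a longer chain in that place would move the number beyond the scatter.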